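Chlorine for methoxy on the pendant aryl ring

This account rests on a few compounds, and the source may have more. Where it says the series, first, only, none or still open, it means among the compounds named here.

Measured compounds:
compound 1 `COc1ccc(-c2c(S(=O)(=O)c3cc(F)cc(F)c3)cnc3c(F)cccc23)cc1` — 2.59 mL/min
compound 2 `COc1cccc(-c2c(S(=O)(=O)c3cc(F)cc(F)c3)cnc3c(F)cccc23)c1` — 2.76 mL/min
compound 3 `COc1ccc(S(=O)(=O)c2cnc3c(F)cccc3c2-c2cccc(OC)c2)cc1` — 2.87 mL/min

In an ADME assay on microsomes from liver (Homo sapiens) for metabolic stability, tested at 2.5 uM (a higher number here means faster removal of the compound, a lower number slower removal), compound 2 gives 2.76 mL/min, the second highest of the three numbers, with compound 3 nearest at 2.87 mL/min and compound 1 furthest at 2.59 mL/min; all three lie within the scatter of one another. Compound 4 `O=S(=O)(c1cc(F)cc(F)c1)c1cnc2c(F)cccc2c1-c1ccc(Cl)cc1` differs from compound 2 by 4-chlorophenyl in place of 3-methoxyphenyl on an aromatic carbon. Among the compounds with values here, the two measured steps, a 1.1-fold higher number from compound 1 to compound 2 (0.03 log units; within the scatter) and a 1.0-fold higher number from compound 2 to compound 3 (0.02 log units; within the scatter), each fall within the scatter, and neither involves the same change, since no measured compound carries a 4-chlorophenyl. On this thin evidence, for compound 4 the expected step is a 1.1-fold higher number from compound 2 to compound 4 (0.02 log units; within the scatter), none beyond the scatter. Compound 4 is therefore estimated at 2.9 mL/min, with a range from 1.5 mL/min to 5.5 mL/min.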

Compound 4, intrinsic clearance in a liver preparation (reported as CLH), per the amount of preparation that the assay uses: 0.73 mL/min
For compound 4 the middle estimate is 4.0-fold (0.60 log units) above the measured one, and the stated range ends above it.
By their numbers in this assay, from the lowest: compound 4; then compounds 1, 2 and 3 (each within the scatter of the next).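

Within the data shown here, with chloro in place of methoxy, this assay shows a 3.5-fold lower number from compound 1 to compound 4 (0.55 log units; beyond the scatter) and, with 4-chlorophenyl in place of 3-methoxyphenyl, a 3.8-fold lower number from compound 2 to compound 4 (0.58 log units; beyond the scatter) as well, the first steps beyond the scatter in this set. Moving the methoxy had given only a 1.1-fold higher number from compound 1 to compound 2 (0.03 log units; within the scatter) so at this aromatic carbon the read-out answers to the replacement of methoxy by chloro, not to where the methoxy sits. Nothing available explains the drop.

From the compounds shown here alone, whether 3-chlorophenyl would match 4-chlorophenyl remains open. So does whether fluoro, methyl or an amine on the pendant ring would give the same drop.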